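A few compounds are considered here, and "the series" means these few. Any claim that something is new, unique, unknown or untested is made for them only; others in the source may bear on it.

Working notes on a series sharing one core, varied only in the group carried on the chain from the aromatic nitrogen.

Compound 1 `CN1CCN(CCCCCCn2c3c(c4ccccc42)C(=O)c2c[n+]([O-])c4ccccc4c2C3=O)CC1` gives 5800 nM in a toxicity assay on HEK-293T cells (Homo sapiens) for cytotoxicity, read by MTT assay, with a stated time of 72 h; a lower number here means a stronger inhibitor, a higher number a weaker inhibitor. Compound 2 `CN(C)CCCCn1c2c(c3ccccc31)C(=O)c1c[n+]([O-])c3ccccc3c1C2=O` gives 520 nM in this assay, and compound 3 `O=C1c2c[n+]([O-])c3ccccc3c2C(=O)c2c1c1ccccc1n2CCCN1CCC(O)CC1` gives 170 nM. Compound 3 is the strongest inhibitor of the three: the steps of a 34-fold lower number from compound 1 to compound 3 (1.53 log units; beyond the scatter) and a 3.1-fold lower number from compound 2 to compound 3 (0.49 log units; beyond the scatter) both lie beyond the scatter, as does an 11-fold lower number from compound 1 to compound 2 (1.05 log units; beyond the scatter).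

Compound 4 `O=C1c2c[n+]([O-])c3ccccc3c2C(=O)c2c1c1ccccc1n2CCCCn1ccnc1` is the next member, not yet measured. Its change from compound 3 is (1H-imidazol-1-yl)methyl in place of 4-hydroxypiperidin-1-yl on a saturated chain carbon, three bonds along the chain from an aromatic nitrogen. All three measured steps concern the same place on the chain, and each one shifted the number by a modest or large amount, so a change here is not expected to pass unnoticed. None of them, however, involved an aromatic ring entering at that position, and none points firmly to a direction. For compound 4 a step of a 3.5-fold higher number from compound 3 to compound 4 (0.55 log units; beyond the scatter) toward a weaker inhibitor is estimated, giving an expected value of 600 nM, with a range from 150 nM to 2500 nM.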

Compound 4, half-maximal inhibitory concentration: 280 nM
Beside the measured number, compound 4's estimate is 2.1-fold (0.33 log units) above it; the range from low to high includes it.
By their numbers in this assay, from the lowest: compounds 3, 4 and 2 (each within the scatter of the next, the first and the last beyond it); then compound 1.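

An aromatic ring enters at this place on the chain with no step beyond the scatter in this assay: (1H-imidazol-1-yl)methyl in place of 4-hydroxypiperidin-1-yl gives a small step (a 1.6-fold higher number from compound 3 to compound 4 (0.22 log units; within the scatter)), and 1H-imidazol-1-yl in place of dimethylamino gives another (a 1.9-fold lower number from compound 2 to compound 4 (0.27 log units; within the scatter)). Among the compounds shown here, compound 4 therefore cannot be told apart from either compound 2 or compound 3, although those two are separated from each other, and among the new steps only the one involving compound 1 is large (a 21-fold lower number from compound 1 to compound 4 (1.32 log units; beyond the scatter)). No measurement shown gives a reason for these steps.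

As far as these compounds go, whether the result extends to another aromatic ring, such as pyridine, at the end of the chain remains open. So does the effect of carrying 1H-imidazol-1-yl on a longer chain.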